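Hexyloxy in Place of Fluoro: Expected Shift in Binding

The source may hold more compounds than are shown below. What is called first, only, known or untested is meant among the compounds shown, and "the series" means these compounds.

Measured compounds:
Compound 1 `CCOc1ccccc1Cc1cnc(N)nc1N`: in an assay for inhibition of Dihydrofolate reductase (Gallus gallus) (a lower number here means a stronger inhibitor, a higher number a weaker inhibitor), compound 1 gives 24500 nM.
Compound 2 `CS(=O)(=O)Oc1ccccc1Cc1cnc(N)nc1N`: in this assay compound 2 gives 22900 nM.
Compound 3 `Nc1ncc(Cc2ccccc2F)c(N)n1`: in this assay compound 3 gives 43700 nM.

Compound 3 has the highest of the three numbers, but its steps to the others are small: a 1.8-fold higher number from compound 1 to compound 3 (0.25 log units; within the scatter) and a 1.9-fold higher number from compound 2 to compound 3 (0.28 log units; within the scatter). The change between the two alkoxy-type compounds, a 1.1-fold lower number from compound 1 to compound 2 (0.03 log units; within the scatter), also stays within the scatter, so the three compounds are not separated on these data.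

Compound 4 `CCCCCCOc1ccccc1Cc1cnc(N)nc1N` differs from compound 3 in one place: hexyloxy in place of fluoro on an aromatic carbon. Among the compounds with values here, the step that bears on it most is a 1.8-fold higher number from compound 1 to compound 3 (0.25 log units; within the scatter), which the new change reverses while lengthening the chain from ethyl to hexyl; no measured step covers that lengthening. Therefore the step expected from this change is estimated as a 2.9-fold lower number from compound 3 to compound 4 (0.46 log units; beyond the scatter), about the size of the ethoxy-to-fluoro step or somewhat larger, a size that rests on little firm ground. For compound 4 the estimate in this assay is 15000 nM, with a range from 4000 nM to 50000 nM.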

Compound 4, inhibition constant: 7940 nM
Estimate against measurement, compound 4: 1.9-fold (0.28 log units) above; the range from low to high includes it.
By their numbers in this assay, from the lowest: compound 4; then compounds 2, 1 and 3 (each within the scatter of the next).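

In this assay, within the data shown here, this position on the aromatic ring now gives steps beyond the scatter, which none of the earlier steps did: hexyloxy in place of fluoro brings a 5.5-fold lower number from compound 3 to compound 4 (0.74 log units; beyond the scatter), and hexyl in place of methylsulfonyl on the same oxygen brings a 2.9-fold lower number from compound 2 to compound 4 (0.46 log units; beyond the scatter). Extending the ethoxy chain to hexyloxy, with butyl in place of hydrogen on the chain, brings a 3.1-fold lower number from compound 1 to compound 4 (0.49 log units; beyond the scatter), so the length of the chain on this oxygen separates compounds here, whereas ethyl and methylsulfonyl did not. Nothing measured here accounts for the lower number of compound 4.

On these data alone, whether the number changes gradually through a butoxy chain, or keeps dropping with a longer chain such as octyloxy, remains open. The compounds also leave open whether an amine or a carboxylic acid at the end of the hexyl chain would preserve the step.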